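This account rests on a few compounds, and the source may have more. Where it says the series, first, only, none or still open, it means among the compounds named here.

Of the compounds shown here, three sharing one core have been measured so far. Compound 1 `COc1ccc(Sc2ccccc2N2CC(C)N(CC(=O)O)CC2C)cc1` gives 580 nM in an assay for inhibition of sodium- and chloride-dependent glycine transporter 1 (Homo sapiens) (on this read-out lower numbers stand for stronger inhibition and higher numbers for weaker inhibition), compound 2 `COc1ccc(Sc2ccccc2N2CCN(CC(=O)O)C(C)(C)C2)cc1` gives 1500 nM, and compound 3 `Cc1ccc(Sc2ccccc2N2CC(C)N(CC(=O)O)CC2C)cc1` gives 550 nM. Compound 3 has the lowest number of the three, but its separation from compound 1 is small: the step from methyl in place of methoxy on an aromatic carbon, a 1.1-fold lower number from compound 1 to compound 3 (0.02 log units; within the scatter), lies within the scatter. Only compound 2, which carries its two methyl groups on a different ring carbon, stands clearly apart, its number being higher than that of compound 3 by an amount beyond the scatter.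

Compound 4 `CC1CN(c2ccccc2Sc2ccc(Cl)cc2)C(C)CN1CC(=O)O` has not yet been measured. It differs from compound 3 by chloro in place of methyl on an aromatic carbon, para to a large group. Among the measured compounds shown here, the single step that touches this position, a 1.1-fold lower number from compound 1 to compound 3 (0.02 log units; within the scatter), showed that exchanging one small group for another there left the number essentially unchanged. For the measured compounds named here, no measured step involves a chloro group. On that basis compound 4 is expected to stay close to compound 3, with a step of about a 1.2-fold lower number from compound 3 to compound 4 (0.09 log units; within the scatter) in this assay. The estimate for compound 4 is 450 nM, expected to fall between 200 nM and 1100 nM.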

Compound 4, half-maximal inhibitory concentration: 360 nM
Compound 4: the middle estimate sits 1.3-fold (0.10 log units) above what was measured; the measured number falls inside the stated range.
By their numbers in this assay, from the lowest: compounds 4, 3 and 1 (each within the scatter of the next); then compound 2.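

The step of chloro in place of methyl, on an aromatic carbon para to a large group, comes in this assay to a 1.5-fold lower number from compound 3 to compound 4 (0.18 log units; within the scatter) and the step of chloro in place of methoxy at that same place comes to a 1.6-fold lower number from compound 1 to compound 4 (0.21 log units; within the scatter) so both lie within the scatter. The earlier compounds had shown only methoxy and methyl here, whereas this position has now carried a halogen as well, and all three pairs among compound 1, compound 3 and compound 4 remain within the scatter of one another, which means that no separation among these three groups can be read from the numbers. No evidence is at hand that would account for these small steps.

The compounds shown leave open whether this position stays as indifferent to groups of another kind, such as an amine, a carboxylic acid or a longer chain like butyl, as it has been to methoxy, methyl and chloro. They also leave open whether chloro in place of methoxy would give a similarly small step on the core of compound 2, where the two methyl groups sit on a different ring carbon.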